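This account rests on a few compounds, and the source may have more. Where it says the series, first, only, none or still open, it means among the compounds named here.

Compound 1 `CC(C)(C)C(=O)N1Cc2c(NC(=O)C3CCNCC3)n[nH]c2C1(C)C`: in a physicochemical assay for solubility, at pH 7 (a lower number here means a less soluble compound, a higher number a more soluble compound), compound 1 gives > 225000 nM, which is a limit of the assay rather than a number.
Compound 2 `CN1CCC(C(=O)N2Cc3c(NC(=O)C4CCC4)n[nH]c3C2(C)C)CC1`: in this assay compound 2 gives > 225000 nM, again a limit of the assay.

Compound 2 therefore stands at the limit, where both values shown sit (the limit of > 225000 nM in this assay, at which 2 of the 2 values shown sit). Compound 3 `CN1CCC(C(=O)N2Cc3c(NC(=O)Nc4cccc(F)c4)n[nH]c3C2(C)C)CC1` differs from compound 2 in one place: (3-fluorophenyl)amino in place of cyclobutyl on a carbonyl carbon. Among the measured compounds shown here, no measured step covers such a change, so the expectation rests on the structures alone. The change is expected to lower solubility beyond the scatter, an at least 2.8-fold lower number from compound 2 to compound 3 (0.44 log units; beyond the scatter). Compound 3 is estimated at 80000 nM, within 15000 nM to 225000 nM.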

Compound 3, solubility: > 225000 nM
Compound 3 gave a limit, no number; the forecaster's own chance of this, stated with the estimate: 35%; middle value at least 2.8-fold (0.44 log units) away from the limit.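

Compound 2 and compound 3 both sit at a limit of this assay, so no step can be read between them. The compounds shown leave open how far (3-fluorophenyl)amino in place of cyclobutyl shifts the read-out, as all of them sit at one limit: the limit of > 225000 nM in this assay, at which 3 of the 3 values shown sit.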